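The source may hold more compounds than are shown below. What is called first, only, known or untested is meant among the compounds shown, and "the series" means these compounds.

Measured so far:
compound 1, `CCCCCCCC/C=C\CCCCCCCC(=O)O[C@@H](C)COP(=O)(O)OC[C@H](N)C(=O)O`: "not active" (no number reported)
compound 2, `CCCCCCCCCCCOc1ccccc1CCC(=O)O[C@H]1COCC[C@H]1OP(=O)(O)OC[C@H](N)C(=O)O`: 3.7%

Of the compounds shown here, two have been tested in an assay on HEK293 cells for agonist activity at probable G-protein coupled receptor 34 (Mus musculus), with a stated time of 1 h; on this read-out lower numbers stand for smaller maximal responses and higher numbers for larger maximal responses. Compound 1 is simply reported as "not active" (no number reported), so no number stands beside it. Going by the values given here, compound 2 is the only compound with a number; in this assay compound 2 gives 3.7%, a small maximal response. Among the compounds with values here, no step between two measured compounds is available, so nothing yet shows how large a change a single structural alteration can bring.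

Compound 3, `CCCCCCCCCCCOc1ccccc1CCC(=O)O[C@@H]1COCC[C@@H]1OP(=O)(O)OC[C@H](N)C(=O)O`, has not been measured. It differs from compound 2 only in the drawn configuration: the two compounds have the same atoms and bonds; at least one stereo element is drawn with a configuration in one of them and without one in the other: 2 of 4 stereo elements differ; a stereocentre at a saturated ring carbon is drawn S in compound 2 and R in compound 3; a stereocentre at a saturated ring carbon is drawn R in compound 2 and S in compound 3. Both stereocentres at saturated ring carbons are thus inverted, while every atom and bond stays the same.

Because compound 2 reaches only 3.7%, the step from it to compound 3 is expected to go upward if anywhere, since there is little room for a smaller response; the step of a number 11.3 percentage points higher from compound 2 to compound 3 (beyond the scatter) is therefore expected to be modest to moderate, with the chance that it stays within the scatter. Compound 3 is estimated at 15%, within a range from 0% to 60%.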

Compound 3, largest response reached (Emax), in percent of the reference or control that the assay uses: 6.4%
Beside the measured number, compound 3's estimate is 8.6 percentage points above it; the range from low to high includes it.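

In this assay, inverting both stereocentres at saturated ring carbons while every atom and bond stays the same gives a number 2.7 percentage points higher from compound 2 to compound 3 (within the scatter). Going by these compounds alone, this is the first single-place comparison, and it shows that this double inversion does not separate the two compounds on this read-out: both maximal responses are small, so swapping these two ring stereocentres together does not turn either compound into a clear agonist at this receptor. One point limits how firmly this can be read as a statement about the two stereocentres: the fact that one of compounds 2 and 3 is drawn with a defined configuration and the other without, at the place where they differ.

The compounds shown leave open whether inverting just one of the two stereocentres would give a different result, since here they change only together. They also leave open whether any change elsewhere would give a clearly larger maximal response on the shared core, for example an amide in place of the ester, or a longer chain in place of the undecyl-type ether chain.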